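The compounds below may be only part of what the source reports. "The series", "measured", "known", "first", "only" and "open" are said of these compounds alone.

Measured compounds:

Compound 1 `ClCc1ccccc1Cn1cnc2c(Cl)nc(Cl)nc21` — in a functional assay on OVCAR-4 cells (Homo sapiens) for cytotoxicity, read by sulforhodamine B assay, with a stated time of 48 h (on this read-out higher numbers stand for weaker inhibition of growth and lower numbers for stronger inhibition of growth), compound 1 gives 3630 nM.
Compound 2 `Nc1nc(Cl)c2ncn(Cc3ccc(CCl)cc3)c2n1` — in this assay compound 2 gives 30200 nM.

Of the two numbers, compound 1 has the lowest; compound 2 stands at a higher number, and the gap between them lies beyond the scatter. Going by the values given here, the two structures differ from each other in more than one place, so the two values show only what they are and carry no single step.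

Compound 3 `Nc1nc(Cl)c2ncn(Cc3ccccc3CCl)c2n1` is not yet measured. It differs from compound 1 in one place: amino in place of chloro on an aromatic carbon. Compound 2 also carries an amino group at the same point of the shared core and gives the weaker of the two measured values, but since compound 2 differs from compound 1 elsewhere as well, that comparison can only suggest a direction. On that basis a step toward weaker growth inhibition is expected, of the size a 4.1-fold higher number from compound 1 to compound 3 (0.62 log units; beyond the scatter), somewhat short of the gap to compound 2. Compound 3 is therefore estimated at 15000 nM in this assay, with a range from 4000 nM to 50000 nM.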

Compound 3, concentration for total growth inhibition: 6460 nM
Beside the measured number, compound 3's estimate is 2.3-fold (0.37 log units) above it; measured number inside the range.
By their numbers in this assay, from the lowest: compounds 1 and 3 (each within the scatter of the next); then compound 2.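

The change of amino in place of chloro on an aromatic carbon, between two ring nitrogen atoms, can now be read on its own. In this assay it amounts to a 1.8-fold higher number from compound 1 to compound 3 (0.25 log units; within the scatter), so at this position, with the rest of the structure held the same, the two groups cannot be told apart on this read-out, even though the amino group brings a hydrogen-bond donor and a hydrogen-bond acceptor that the chloro group does not. Going by these compounds alone, until now the amino group had been seen only in compound 2, which differs from compound 1 in more than one place, and nothing measured here explains why this single change leaves the values within the scatter of each other.

The compounds shown leave open whether this tolerance extends to other groups on the same carbon, such as a methoxy group, a dimethylamino group or plain hydrogen. They also leave open whether the same change would give a comparable step if the chloro group on the other aromatic carbon were replaced by an amine.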